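Notes on compound 4: hydroxycarbamoyl replaced by aminophenyl carbamoyl

A few compounds are considered here, and "the series" means these few. Any claim that something is new, unique, unknown or untested is made for them only; others in the source may bear on it.

Measured in an assay on isolated protein for inhibition of protein deacetylase HDAC6 (Homo sapiens), read by fluorescence (a lower number here means a stronger inhibitor, a higher number a weaker inhibitor), so far:
compound 1 `Cn1cc(-c2ccccc2Oc2ccccc2)c2cc(C(=O)NCCCC(=O)NO)[nH]c2c1=O`: 144 nM
compound 2 `Cc1cc(F)cc(C)c1Oc1ccc(C(C)(C)O)cc1-c1cn(C)c(=O)c2[nH]c(C(=O)NCCCCCCC(=O)NO)cc12`: 17.2 nM
compound 3 `Cn1cc(-c2ccccc2Oc2ccccc2)c2cc(C(=O)NCc3ccc(C(=O)NO)cc3)[nH]c2c1=O`: 15.3 nM

Compound 1 stands highest of the three numbers in this assay; compound 2 and compound 3 both give lower numbers, and both gaps lie beyond the scatter. For the measured compounds named here, the only single-place step from compound 1 is a 9.4-fold lower number from compound 1 to compound 3 (0.97 log units; beyond the scatter), which exchanges the chain while keeping the hydroxycarbamoyl group in place. Compound 2 differs from compound 1 in more than one place, so its value is read only as a second number below compound 1.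

Compound 4 `Cn1cc(-c2ccccc2Oc2ccccc2)c2cc(C(=O)NCCCCC(=O)Nc3ccccc3N)[nH]c2c1=O` is the next member. Relative to compound 1 the change is ((2-aminophenyl)carbamoyl)methyl in place of hydroxycarbamoyl on a saturated chain carbon, three bonds along the chain from an amide-type nitrogen. Going by the values given here, no measured step touches the hydroxycarbamoyl group itself; a 9.4-fold lower number from compound 1 to compound 3 (0.97 log units; beyond the scatter) bears on it only in showing that the chain between the amide-type nitrogen and that group moves the number by a modest amount. Among the compounds with values here, with no direct precedent, the expected step is set as a 5.6-fold higher number from compound 1 to compound 4 (0.74 log units; beyond the scatter), with a wide range. Compound 4 is thus expected to give about 800 nM in this assay, between 150 nM and 6000 nM.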

Compound 4, half-maximal inhibitory concentration: > 500 nM
Compound 4 was reported as a limit; the forecaster's own chance of this, stated with the estimate: 15%; the middle value lies beyond the limit too.
By their numbers in this assay, from the lowest: compounds 3 and 2 (each within the scatter of the next); then compound 1. At a limit, above all of these: compound 4.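

For the compounds shown here, this is the first measured change to the hydroxycarbamoyl group itself. In this assay, exchanging it for ((2-aminophenyl)carbamoyl)methyl gives an at least 3.4-fold higher number from compound 1 to compound 4 (0.54 log units; beyond the scatter), whereas the earlier step, a 9.4-fold lower number from compound 1 to compound 3 (0.97 log units; beyond the scatter), kept that group and moved the number the other way. The group that leaves and the group that enters match in hydrogen-bond donors and acceptors, so the step arises without a difference in those counts, and compound 4 is reported as a limit, not a number: the limit of > 500 nM in this assay, at which 1 of the 4 values shown sits.

As far as these compounds go, how far compound 4 lies past that limit stays open. The data also do not separate the extra methylene from the aminophenyl group within the step. Also open, from the compounds shown here alone, is how a carboxylic acid or a primary amide in place of hydroxycarbamoyl would read on this chain.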